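A few compounds are considered here, and "the series" means these few. Any claim that something is new, unique, unknown or untested is made for them only; others in the source may bear on it.

Among the measured compounds shown here, compound 2 `Cc1cnc(Nc2ccc(C(C)C)cc2)nc1Nc1nc2ccccc2s1` is one of three compounds measured here. In a functional assay on HeLa cells (Homo sapiens) for antiproliferative activity, read by MTT assay, with a stated time of 48 h (a higher number here means a weaker inhibitor, a lower number a stronger inhibitor), compound 2 gives only a limit, > 50000 nM, so its place on the scale is known only as an edge, not as a number. The other two measured compounds share a core with compound 2 but differ from it at more than one place. Compound 1 `Cc1ccc2nc(Nc3nc(Nc4ccc(S(N)(=O)=O)cc4)ncc3F)sc2c1` gives 1890 nM in this assay, and compound 3 `NS(=O)(=O)c1ccc(Nc2ncc(F)c(Nc3nc4ccc(Cl)cc4s3)n2)cc1` gives 8770 nM. For the measured compounds named here, the single one-place step measured is a 4.6-fold higher number from compound 1 to compound 3 (0.67 log units; beyond the scatter).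

Compound 4 `COc1cccc(Nc2ncc(C)c(Nc3nc4ccccc4s3)n2)c1` differs from compound 2 in one place: 3-methoxyphenyl in place of 4-isopropylphenyl on a nitrogen on an aromatic ring. Going by the values given here, no measured step concerns a change of this kind. The step from compound 1 to compound 3 touches a different place on the shared core, so it gives no guide to the direction or the size of this change. Because compound 2 sits at the limit of > 50000 nM in this assay, at which 1 of the 3 values shown sits, a number for compound 4 would appear only if the change brought a large gain, and nothing measured points to one. Compound 4 is therefore expected to stay weak, with an estimated 30000 nM and a range of 5000 nM to 100000 nM. That estimate amounts to an expected step of an at least 1.6-fold lower number from compound 2 to compound 4 (0.22 log units; that floor lies within the scatter).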

Compound 4, half-maximal inhibitory concentration: > 50000 nM
Compound 4 ended at the assay's limit; the forecaster's own chance of this, stated with the estimate: 50%; middle value at least 1.6-fold (0.22 log units) from the limit.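

Compound 2 and compound 4 both stop at a limit in this assay rather than at a number, so no step between them can be read: the limit of > 50000 nM in this assay, at which 2 of the 4 values shown sit.

The compounds shown leave open whether 3-methoxyphenyl in place of 4-isopropylphenyl changes the antiproliferative activity at all, and if so, in which direction and by how much.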